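The compounds below may be only part of what the source reports. "The series", "measured", "known", "first", "only" and "open" are said of these compounds alone.

Compound 3 `CCC(CC)C(N)CCN(C(=O)[C@@H]1C[C@H]1c1ccccc1)c1ccc(-c2ccccc2)cc1` stands at the high end of the three measured compounds: in a functional assay for agonist activity at G protein-coupled receptor 88 (Homo sapiens), read by HTRF and cAMP accumulation (a lower number here means that less compound is needed, a higher number that more compound is needed for the effect), compound 3 gives 2 nM, while compound 1 `CC[C@@H](C)[C@H](N)CN(C(=O)[C@@H]1C[C@H]1c1ccccc1)c1ccc(-c2ccccc2)cc1` gives 1.4 nM and compound 2 `NC1(CN(C(=O)[C@@H]2C[C@H]2c2ccccc2)c2ccc(-c3ccccc3)cc2)CCCC1` gives 0.57 nM. Against compound 1 that difference is only a 1.4-fold higher number from compound 1 to compound 3 (0.15 log units; within the scatter), whereas a 3.5-fold higher number from compound 2 to compound 3 (0.55 log units; beyond the scatter). Compound 4 `O=C([C@@H]1C[C@H]1c1ccccc1)N(CCNCC1CCCCC1)c1ccc(-c2ccccc2)cc1` brings a different kind of change: (cyclohexylmethyl)amino in place of 1-amino-2-ethylbutyl on a saturated chain carbon, two bonds along the chain from an amide-type nitrogen. For the measured compounds named here, every measured step so far reshapes the group carrying the amine, and each stayed modest, for example a 2.5-fold lower number from compound 1 to compound 2 (0.39 log units; beyond the scatter). Going by the values given here, since no measured pair tests a secondary amine with a cyclohexylmethyl group, the expected step is taken as small and uncertain in direction, leaning slightly toward a higher number. Compound 4 is therefore estimated at 3.5 nM, within a range of 0.8 nM to 15 nM, meaning a 1.8-fold higher number from compound 3 to compound 4 (0.24 log units; within the scatter).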

Compound 4, half-maximal effective concentration: 6.6 nM
Beside the measured number, compound 4's estimate is 1.9-fold (0.28 log units) below it; the measured number falls inside the stated range.
By their numbers in this assay, from the lowest: compound 2; then compounds 1 and 3 (each within the scatter of the next); then compound 4.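

For the compounds shown here, the (cyclohexylmethyl)amino group gives the first large step, a 12-fold higher number from compound 2 to compound 4 (1.06 log units; beyond the scatter), while the other two steps are modest: a 3.3-fold higher number from compound 3 to compound 4 (0.52 log units; beyond the scatter) and a 4.7-fold higher number from compound 1 to compound 4 (0.67 log units; beyond the scatter). A ring alone does not account for this, since compound 2 also carries one and has the lowest number. No measurement shown here explains the shift.

Still open, from the compounds shown here alone, is whether the higher number follows from the substituent on the amine nitrogen or from the cyclohexyl ring itself. A methylamino or benzylamino group at this place could help separate the two.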